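The source may report more compounds than this note shows. Statements on the series, on what has been measured and on what is new or still open speak of the compounds shown alone.

For the measured compounds named here, compound 3 `Cn1c(N2N=C(c3ccccc3)CC2c2ccc(F)cc2)nc(-c2ccccc2)c(C#N)c1=O` stands second highest of the three numbers known so far: in a functional assay on HT-29 cells (Homo sapiens) for antiproliferative activity, with a stated time of 72 h (on this read-out higher numbers stand for weaker inhibition and lower numbers for stronger inhibition), compound 3 gives 8150 nM, while compound 1 `Cn1c(N2N=C(c3ccccc3)CC2c2ccccc2)nc(-c2ccccc2)c(C#N)c1=O` gives 2490 nM and compound 2 `COc1ccc(C2CC(c3ccccc3)=NN2c2nc(-c3ccccc3)c(C#N)c(=O)n2C)cc1` gives 14700 nM. Compound 4 `Cc1ccc(C2=NN(c3nc(-c4ccccc4)c(C#N)c(=O)n3C)C(c3ccc(F)cc3)C2)cc1` differs from compound 3 by methyl in place of hydrogen on an aromatic carbon. Going by the values given here, two measured steps bear on this, if only loosely, since neither involves a methyl group: a 3.3-fold higher number from compound 1 to compound 3 (0.51 log units; beyond the scatter) and a 5.9-fold higher number from compound 1 to compound 2 (0.77 log units; beyond the scatter). Both show that adding a group on an aromatic carbon raised the number, so a small step upward in this assay is expected, a 1.3-fold higher number from compound 3 to compound 4 (0.13 log units; within the scatter), with no confidence that it clears the scatter. Compound 4 is therefore estimated at 11000 nM, within a range from 4000 nM to 30000 nM.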

Compound 4, half-maximal inhibitory concentration: 4620 nM
Beside the measured number, compound 4's estimate is 2.4-fold (0.38 log units) above it, within the range that was stated.
By their numbers in this assay, from the lowest: compounds 1, 4, 3 and 2 (each within the scatter of the next, the first and the last beyond it).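

In this assay, methyl in place of hydrogen on this phenyl ring gives a 1.8-fold lower number from compound 3 to compound 4 (0.25 log units; within the scatter), so this change does not separate compound 4 from compound 3. For the compounds shown here, the earlier methoxy and fluoro additions sat on the other phenyl ring and each gave a step beyond the scatter, whereas methyl at this new position gives no such step. Nothing measured here offers an explanation for this result.

Going by these compounds, whether an amine, a carboxylic acid or a longer chain at this position would also stay within the scatter remains open. So does whether methyl would give the same result without the fluoro on the other ring.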